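The compounds below may be only part of what the source reports. "The series", "measured", "known", "first", "only" and "open" are said of these compounds alone.

Compound 1 `CCN(CC)c1cc2[nH]c(C3CCCCC3)nc2cc1NC(=O)c1cnccn1`: in an ADME assay on Vero cells (Chlorocebus sabaeus) for cytotoxicity, read by resazurin assay, with a stated time of 3 days (a lower number here means a stronger inhibitor, a higher number a weaker inhibitor), compound 1 gives > 100 ug/mL, a limit of the assay.
Compound 2 `CCCNC(=O)Nc1cc2nc(C3CCCCC3)[nH]c2cc1N(CC)CC`: compound 2 gives > 100 ug/mL, likewise a limit.
Compound 3 `CCc1ccc(C(=O)Nc2cc3nc(C4CCCCC4)[nH]c3cc2N(CC)CC)cc1`: compound 3 gives > 100 ug/mL, again a limit.

Compound 3 therefore stands nowhere that a number could place it: its value is one of the three that sit at the limit of > 100 ug/mL in this assay, at which 3 of the 3 values shown sit. Compound 4 `CCN(CC)c1cc2[nH]c(C3CCCCC3)nc2cc1NC(=O)NCc1ccccc1` differs from compound 3 in that (benzylamino in place of 4-ethylphenyl on a carbonyl carbon). The measured steps that touch the same carbonyl carbon, a step that the two limits leave unreadable from compound 1 to compound 3, a step that the two limits leave unreadable from compound 2 to compound 3 and a step that the two limits leave unreadable from compound 1 to compound 2, are all of unreadable size, so they give no direction. Compound 4 is accordingly expected to remain at the same limit, with an estimate of 100 ug/mL spanning 50 ug/mL to 200 ug/mL. The expected step of a number no higher from compound 3 to compound 4 (the limit leaves the size open) is thus none beyond the scatter.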

Compound 4, half-maximal inhibitory concentration: > 100 ug/mL
Compound 4 ended at the assay's limit; the forecaster's own chance of this, stated with the estimate: 85%; the middle value sits exactly at the limit.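

In this assay, the steps from compound 1, compound 2 and compound 3 to compound 4 cannot be read, since all four values are limits: the limit of > 100 ug/mL in this assay, at which 4 of the 4 values shown sit.

The compounds shown leave open what number any of them would give, and whether any group on the carbonyl carbon would yield a readable value.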